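The source may hold more compounds than are shown below. What is called first, only, known or untested is meant among the compounds shown, and "the series" means these compounds.

Measured in a functional assay on L5178Y cells (Mus musculus) for inhibition, read by MTT assay, with a stated time of 24 h; a higher number here means a weaker inhibitor, a lower number a stronger inhibitor:
- Compound 1 `Oc1ccc([C@@H]2C/C(=N\Nc3cnccn3)c3c(O)cc(O)cc3O2)cc1`: >= 11300 nM
- Compound 2 `Oc1ccc([C@@H]2C/C(=N\N=C\c3c[nH]c4ccccc34)c3c(O)cc(O)cc3O2)cc1`: >= 11300 nM
- Compound 3 `COc1cc(O)c2c(c1)O[C@H](c1ccc(OCC3CO3)cc1)CC2=O`: >= 11300 nM

Every entry here is a limit of the assay, not a number. For the measured compounds named here, the whole series so far is described by the limit of >= 11300 nM in this assay, at which 3 of the 3 values shown sit.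

Compound 3 offers only a limit, >= 11300 nM.

Compound 4 `COc1cc(O)c2c(c1)O[C@H](c1ccc(OCC(O)CCl)cc1)CC2=O` differs from compound 3 as follows: 2-chloro-1-hydroxyethyl in place of oxiran-2-yl on a saturated chain carbon bound to an oxygen on an aromatic ring. The three-membered non-aromatic ring leaves, and the new group has no ring.

Going by the values given here, no measured step in this assay speaks to this change, so no shift beyond the scatter is expected, in either direction. A further limit is the likeliest report.

The estimate for compound 4 is an expected 14000 nM, with an expected range from 6000 nM to 30000 nM.

This estimate means an expected step that the limit leaves unreadable from compound 3 to compound 4.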

Compound 4, half-maximal inhibitory concentration: >= 11300 nM
Compound 4: no number, only a limit; the forecaster's own chance of this, stated with the estimate: 65%; the middle value lies beyond the limit too.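

Compound 3 and compound 4 both give only a limit in this assay, so no step can be read between them. The compounds shown leave open whether 2-chloro-1-hydroxyethyl in place of oxiran-2-yl changes inhibition at all.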